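The compounds below may be only part of what the source reports. "The series", "measured", "known", "first", "only" and "open" are said of these compounds alone.

In an ADME assay for permeability (on this read-out higher numbers stand for higher permeability and lower numbers for lower permeability), compound 1 `CNC(=O)c1cc(C(=O)NC2CCOCC2)n([C@@H](C)c2ccccc2)n1` gives 270 nm/s and compound 3 `CNC(=O)c1cc(C(=O)N[C@H]2CC[C@H](O)CC2)n([C@@H](C)c2ccc(C(F)(F)F)cc2)n1` gives 270 nm/s on the same scale. Compound 2 `CNC(=O)c1cc(C(=O)N[C@H]2CC[C@H](O)CC2)c([C@@H](C)c2cccc(C)c2)o1` gives 85 nm/s and so stands lowest of the three, with compound 1 and compound 3 each higher by a margin beyond the usual scatter of repeat measurements.

Compound 4 `CNC(=O)c1cc(C(=O)N[C@H]2CC[C@H](O)CC2)c([C@@H](C)c2ccc(C)cc2)o1` has not yet been measured. It has the same atoms as compound 2, joined differently: 4-methylphenyl in place of 3-methylphenyl on a saturated chain carbon bound to an aromatic carbon and a saturated chain carbon. Put simply, 4-methylphenyl stands in place of 3-methylphenyl on a saturated chain carbon bound to an aromatic carbon and a saturated chain carbon, so 1-(3-methylphenyl)ethyl becomes 1-(4-methylphenyl)ethyl. Everything else in compound 2 stays as it is.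

For the measured compounds named here, no two measured compounds differ in only one place, so the data do not show directly how large a change of this kind can be in this assay. The expectation therefore starts from compound 2 at 85 nm/s and moves little from there. The expected step of a 1.1-fold higher number from compound 2 to compound 4 (0.02 log units; within the scatter) is none beyond the scatter, and no direction is favoured. The estimate for compound 4 is 90 nm/s with an expected range from 45 nm/s to 180 nm/s.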

Compound 4, apparent permeability in the ADME assay: 108 nm/s
Beside the measured number, compound 4's estimate is 1.2-fold (0.08 log units) below it, and the stated range covers the measured number.
By their numbers in the ADME assay, from the lowest: compounds 2 and 4 (each within the scatter of the next); then compounds 1 and 3 (each within the scatter of the next).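

For the compounds shown here, this pair is the first in the set that differs in one place, so it gives a direct reading of a change at this spot in the ADME assay: when 1-(3-methylphenyl)ethyl becomes 1-(4-methylphenyl)ethyl, the result is a small step (a 1.3-fold higher number from compound 2 to compound 4 (0.10 log units; within the scatter)). Going by these compounds alone, on this read-out, then, 3-methylphenyl and 4-methylphenyl on a saturated chain carbon cannot be told apart, although this rests on one pair and makes no rule for other compounds. In a physicochemical assay for solubility, read by HPLC, in simulated intestinal fluid, with a stated time of 16 h, at pH 6.5 (a higher number here means a more soluble compound, a lower number a less soluble compound), the same pair offers no readable step, since neither compound gives a number and both sit at a limit of the assay: the limit of > 1000 ug/mL in the physicochemical assay, at which 2 of the 2 values shown sit. In the physicochemical assay compound 2 gives > 1000 ug/mL and this is a limit of the assay, not a number. In the physicochemical assay compound 4 gives > 1000 ug/mL and this too is a limit of the assay, not a number.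

A single shift of the methyl group says little about how much a larger change at this place could do, so a phenyl ring carrying an amine or a carboxylic acid in place of the methyl remains an open case. Compound 1 and compound 3 differ from this pair in more than one place, so what separates them from compound 2 and compound 4 also stays unresolved.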